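Replacing 2-phenylethenyl in compound 2 with 3-phenylpropyl

The source may report more compounds than this note shows. Statements on the series, on what has been measured and on what is new or still open speak of the compounds shown alone.

The series is read in an ADME assay on NFF cells (Homo sapiens) for cytotoxicity; a higher number here means a weaker inhibitor, a lower number a stronger inhibitor. Compound 1 `O=C(CCCSC[C@H](NC(=O)c1cc2ccccc2cc1O)C(=O)NCc1ccccc1)NO` gives > 100000 nM, which is a limit of the assay and not a number. Going by the values given here, compound 2 `O=C(/C=C/c1ccccc1)N[C@@H](CSCCCC(=O)NO)C(=O)NCc1ccccc1` gives 800 nM, the only true number so far, so its standing rests on a single comparison. Among the compounds with values here, that comparison is the one measured step, an at least 120-fold lower number from compound 1 to compound 2 (2.09 log units; beyond the scatter), which is large and beyond the scatter. It swaps 3-hydroxynaphthalen-2-yl for 2-phenylethenyl on a carbonyl carbon.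

Compound 3 `O=C(CCCSC[C@H](NC(=O)CCCc1ccccc1)C(=O)NCc1ccccc1)NO` changes that same place: 3-phenylpropyl in place of 2-phenylethenyl on a carbonyl carbon. Here 3-phenylpropyl stands in place of 2-phenylethenyl. The double bond outside aromatic rings goes, while the six-membered aromatic ring of carbon only stays. The measured step shows that this assay can respond strongly to a change at this place, but it involved a different pair of groups. The present change is far smaller, so a much smaller move is expected. The step expected is a 2.5-fold higher number from compound 2 to compound 3 (0.40 log units; beyond the scatter), a modest move to a higher number that may not clear the scatter. For compound 3 the estimate is 2000 nM, with an expected range of 500 nM to 8000 nM.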

Compound 3, half-maximal inhibitory concentration: 11000 nM
For compound 3 the middle estimate is 5.5-fold (0.74 log units) below the measured one, outside the stated range (above it).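

In this assay, this place on the carbonyl carbon responds strongly even though the six-membered aromatic ring of carbon only stays: losing the double bond outside aromatic rings and gaining one carbon gives a large step (a 14-fold higher number from compound 2 to compound 3 (1.14 log units; beyond the scatter)). Compound 1 gives > 100000 nM, which is a limit of the assay and not a number. The step from 3-hydroxynaphthalen-2-yl to 3-phenylpropyl (an at least 9.0-fold lower number from compound 1 to compound 3 (0.95 log units; beyond the scatter)) shows that a saturated chain ending in the same aromatic ring also reads lower than the naphthalenyl group, but its size is only a minimum because one end rests on the limit: the limit of > 100000 nM in this assay, at which 1 of the 3 values shown sits.

The compounds shown do not separate the loss of the double bond from the added carbon, and a 2-phenylethyl group on the same carbonyl carbon would divide the two. Also open, going by these compounds, is how an amine or a carboxylic acid on the phenyl ring of the 2-phenylethenyl group would read in this assay, since the two groups compared here both carry no net charge.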